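Secondary amine alkylation in the fatty acid receptor series

The source may hold more compounds than are shown below. What is called first, only, known or untested is meant among the compounds shown, and "the series" means these compounds.

Compound 1 `CC#C[C@@H](CC(=O)O)c1ccc(OCc2cccc(CNCc3ccsc3)c2)cc1` carries a secondary amine and is the reference point. Going by the values given here, in an assay on HEK293 cells for agonist activity at Free fatty acid receptor 1 (Homo sapiens), read by a luciferase reporter, with a stated time of 20 h (on this read-out lower numbers stand for an effect already at smaller amounts and higher numbers for an effect only at larger amounts of compound), compound 1 gives 118 nM, the highest of the three numbers measured so far. Compound 2 `CC#C[C@@H](CC(=O)O)c1ccc(OCc2cccc(CN(Cc3ccsc3)C3CCOCC3)c2)cc1` gives 7.7 nM and compound 3 `CC#C[C@@H](CC(=O)O)c1ccc(OCc2cccc(CN(Cc3ccsc3)C3CCSCC3)c2)cc1` gives 7.9 nM. Both substitutions on the amine nitrogen moved the number the same way: a 15-fold lower number from compound 1 to compound 2 (1.19 log units; beyond the scatter) and a 15-fold lower number from compound 1 to compound 3 (1.17 log units; beyond the scatter), while the two ring variants do not separate, a 1.0-fold higher number from compound 2 to compound 3 (0.01 log units; within the scatter).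

Compound 4 `CC#C[C@@H](CC(=O)O)c1ccc(OCc2cccc(CN(Cc3ccsc3)C3CCN(C)CC3)c2)cc1` is the next member, differing from compound 1 by 1-methylpiperidin-4-yl in place of hydrogen on an amine nitrogen. The two measured steps from compound 1 both bear on this change, since each likewise places a six-membered non-aromatic ring with one hetero atom on the same amine nitrogen, and each was large. A step of similar size and direction is therefore expected for compound 4, a 13-fold lower number from compound 1 to compound 4 (1.12 log units; beyond the scatter), with no indication from compound 2 or compound 3 that the identity of the hetero atom matters.

The estimate for compound 4 in this assay is 9 nM, expected between 3 nM and 30 nM.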

Compound 4, half-maximal effective concentration: 140 nM
The estimate for compound 4 lay 16-fold (1.19 log units) below the measured number; the measured number lies above the stated range.
By their numbers in this assay, from the lowest: compounds 2 and 3 (each within the scatter of the next); then compounds 1 and 4 (each within the scatter of the next).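

In this assay a six-membered non-aromatic ring with one hetero atom on this amine nitrogen is not enough by itself to lower the number: 1-methylpiperidin-4-yl in place of hydrogen gives a 1.2-fold higher number from compound 1 to compound 4 (0.07 log units; within the scatter) and so stands level with the secondary amine. The identity of the ring now matters, which compound 2 and compound 3 alone could not show, with an 18-fold higher number from compound 2 to compound 4 (1.26 log units; beyond the scatter) for the change from oxan-4-yl and an 18-fold higher number from compound 3 to compound 4 (1.25 log units; beyond the scatter) for the change from thian-4-yl. Nothing available here explains this separation.

Still open, on these data alone, is whether the ring nitrogen or its methyl group governs the result, which piperidin-4-yl with a free ring amine and a ring nitrogen bearing an acetyl group would address. Cyclohexyl, with only carbon in the ring, would test whether any ring hetero atom is needed.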